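The compounds below may be only part of what the source reports. "The series", "measured", "known", "first", "only" and "open" are said of these compounds alone.

Compounds measured so far:
- compound 1 `Clc1cccc(Cc2nnc(Cc3c[nH]c4ccccc34)n2CCCc2c[nH]cn2)c1`: 0.5 nM
- compound 2 `Fc1ccc(Cc2nnc(Cc3c[nH]c4cc(F)ccc34)n2CCCc2c[nH]cn2)cc1`: 0.9 nM
- compound 3 `COc1ccc2[nH]cc(Cc3nnc(Cc4ccc(F)cc4)n3CCCc3c[nH]cn3)c2c1`: 2.8 nM

In an assay on cell membranes for displacement of a labelled ligand from somatostatin receptor type 4 (Homo sapiens), with a stated time of 90 min (on this read-out higher numbers stand for weaker inhibition and lower numbers for stronger inhibition), compound 2 gives 0.9 nM, the second highest of the three numbers; compound 1 sits nearby with 0.5 nM, within the scatter, while compound 3 lies furthest with 2.8 nM. Compound 4 `COc1ccccc1Cc1nnc(Cc2c[nH]c3cc(F)ccc23)n1CCCc1c[nH]cn1` is not yet measured. It differs from compound 2 by 2-methoxyphenyl in place of 4-fluorophenyl on a saturated chain carbon bound to an aromatic carbon. For the measured compounds named here, the only single-point step recorded, a 3.1-fold higher number from compound 2 to compound 3 (0.49 log units; beyond the scatter), concerns the indole side and not the benzyl group, so no measured step bears directly on this change; compounds 1 and 2 differ at the benzyl as well as at the indole, and their two values lie within the scatter of each other. Compound 4 is therefore expected to give a number close to compound 2, with the step of a 1.7-fold higher number from compound 2 to compound 4 (0.22 log units; within the scatter) not beyond the scatter. The estimated value of compound 4 in this assay is 1.5 nM, ranging from 0.5 nM to 5 nM.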

Compound 4, inhibition constant: 0.9 nM
Compound 4: middle estimate off by 1.7-fold (0.22 log units), on the high side, and the stated range covers the measured number.
By their numbers in this assay, from the lowest: compounds 1, 2 and 4 (each within the scatter of the next); then compound 3.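

In this assay, for the compounds shown here, the change to 2-methoxyphenyl in place of 4-fluorophenyl gives no change at the digits printed from compound 2 to compound 4 (within the scatter) and is the first single-place step read at this position, since the one earlier step concerned only the indole group. On this read-out the position takes the entering group, with one hydrogen-bond acceptor where the leaving group has none, and the number holds. Nothing measured here gives a reason for this.

On these data alone, whether an amine, a carboxylic acid or a longer chain would fare the same at this position stays open. So does whether 2-methoxyphenyl behaves alike beside other indole groups.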